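This account rests on a few compounds, and the source may have more. Where it says the series, first, only, none or still open, it means among the compounds named here.

Measured compounds:
compound 1, `N#Cc1cnc(NCc2cnccc2C(F)(F)F)cc1NC[C@H]1CC[C@@H](O)CC1`: 58 nM
compound 2, `CC1(C)C[C@H](Nc2cc(NCc3cnccc3C(F)(F)F)ncc2C#N)CC(C)(C)[C@H]1O`: 20 nM

In an assay on isolated protein for inhibition of protein kinase C theta type (Homo sapiens), read by TR-FRET, with a stated time of 2 h (a lower number here means a stronger inhibitor, a higher number a weaker inhibitor), compound 1 gives 58 nM, the higher of the two numbers recorded so far; compound 2 gives 20 nM, and the gap between the two lies beyond the usual scatter of this assay. Compound 3, `CC1(C)C[C@H](Nc2cc(NCc3cnccc3C(F)(F)F)ncc2C#N)CC[C@@H]1O`, has not yet been measured. It differs from compound 1 in one place: 4-hydroxy-3,3-dimethylcyclohexyl in place of (4-hydroxycyclohexyl)methyl on a nitrogen on an aromatic ring. The ring with its hydroxyl is thus attached directly to the nitrogen, as in compound 2, though compound 2 carries further methyl groups. Because compound 2 reaches 20 nM while compound 1 stands at 58 nM, compound 3 is expected to land between the two, a step of a 1.9-fold lower number from compound 1 to compound 3 (0.29 log units; within the scatter) toward a lower number, modest but likely beyond the scatter. The estimate for compound 3 in this assay is 30 nM, within a range from 12 nM to 75 nM.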

Compound 3, half-maximal inhibitory concentration: 7 nM
Beside the measured number, compound 3's estimate is 4.3-fold (0.63 log units) above it; the whole stated range lies above it.
By their numbers in this assay, from the lowest: compound 3; then compound 2; then compound 1.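

In this assay, replacing (4-hydroxycyclohexyl)methyl with 4-hydroxy-3,3-dimethylcyclohexyl on this nitrogen gives an 8.3-fold lower number from compound 1 to compound 3 (0.92 log units; beyond the scatter), so this position responds clearly to a change in the group it carries. The entering group has one more heavy atom, while the six-membered ring and the counts of hydrogen-bond donors and acceptors stay the same, so the step needs no added donor or acceptor. Nothing available explains why the number falls.

This one step changes two features at once, so the compounds shown do not separate the loss of the carbon linking ring and nitrogen from the gain of the two ring methyl groups. They also leave open whether the hydroxyl is needed, as an amine or a methoxy group at that ring position would test.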